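Replacing the 2-methoxyphenyl group in compound 3

A few compounds are considered here, and "the series" means these few. Any claim that something is new, unique, unknown or untested is made for them only; others in the source may bear on it.

In a functional assay on MDA-MB-436 cells (Homo sapiens) for antiproliferative activity, read by MTT assay, with a stated time of 48 h (a lower number here means a stronger inhibitor, a higher number a weaker inhibitor), compound 1 (`CN1CCN(c2ccc(-c3cc4c(N5CCN(C(=O)Nc6ccccc6)CC5)ncnc4s3)cc2)CC1`) gives 7090 nM, compound 2 (`COc1ccc(NC(=O)N2CCN(c3ncnc4sc(-c5ccc(N6CCN(C)CC6)cc5)cc34)CC2)cc1`) gives 30100 nM and compound 3 (`COc1ccccc1NC(=O)N1CCN(c2ncnc3sc(-c4ccc(N5CCN(C)CC5)cc4)cc23)CC1`) gives 26300 nM. Compound 3 thus lies within the scatter of compound 2 and has a higher number than compound 1. Compound 4 (`CN1CCN(c2ccc(-c3cc4c(N5CCN(C(=O)Nc6ccc(Cl)c(C(F)(F)F)c6)CC5)ncnc4s3)cc2)CC1`) carries 4-chloro-3-(trifluoromethyl)phenyl in place of 2-methoxyphenyl on an amide-type nitrogen. Adding methoxy raised the number modestly, a 4.2-fold higher number from compound 1 to compound 2 (0.63 log units; beyond the scatter) and a 3.7-fold higher number from compound 1 to compound 3 (0.57 log units; beyond the scatter), while its relocation gave only a 1.1-fold lower number from compound 2 to compound 3 (0.06 log units; within the scatter). Within the data shown here, removing methoxy should reverse a step of that size, but no measured compound carries the entering group, so the range stays wide. The expected change is modest, a 3.8-fold lower number from compound 3 to compound 4 (0.57 log units; beyond the scatter). Compound 4 is estimated at 7000 nM, within 2000 nM to 25000 nM.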

Compound 4, half-maximal inhibitory concentration: 3500 nM
Beside the measured number, compound 4's estimate is 2.0-fold (0.30 log units) above it, and the stated range covers the measured number.
By their numbers in this assay, from the lowest: compound 4; then compound 1; then compounds 3 and 2 (each within the scatter of the next).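

At this position on the amide-type nitrogen, 4-chloro-3-(trifluoromethyl)phenyl gives a 7.5-fold lower number from compound 3 to compound 4 (0.88 log units; beyond the scatter) and an 8.6-fold lower number from compound 2 to compound 4 (0.93 log units; beyond the scatter), so the methoxy compounds are not the lower limit of what a substituted phenyl can reach. It also gives a 2.0-fold lower number from compound 1 to compound 4 (0.31 log units; beyond the scatter), the first step below the unsubstituted phenyl, whereas both methoxy groups went the other way. No available data bear on the reason for these steps.

Going by these compounds, whether the chloro or the trifluoromethyl part carries the step stays open. So does the effect of a nitrile or a carboxylic acid on this phenyl ring.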